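This account rests on a few compounds, and the source may have more. Where it says the series, first, only, none or still open, it means among the compounds named here.

Of the compounds shown here, three have been measured in an assay on ileum (strain Hartley) with 5-hydroxytryptamine receptor 3A (Cavia porcellus) as the target (a higher number here means a larger maximal response, a lower number a smaller maximal response), and all three share a core that differs only in the groups placed on its six-membered aromatic ring. Compound 1 `Cc1cccc2nc(N3CCN(C)CC3)oc12` gives 0.58. Compound 2 `COc1cc(Cl)cc2nc(N3CCN(C)CC3)oc12` gives 0.62. Compound 3 `COc1cc(C)cc2nc(N3CCN(C)CC3)oc12` gives 0.56. The three numbers lie close together, and none of the gaps among them is larger than the ordinary scatter of repeated measurements.

Compound 3 and compound 2 differ in one place, and the change is chloro in place of methyl on an aromatic carbon. The step it made is a number 0.060 higher from compound 3 to compound 2 (within the scatter).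

Compound 4 `CN1CCN(c2nc3cccc(Cl)c3o2)CC1` has not yet been measured. It is built from compound 1 by the change (chloro in place of methyl on an aromatic carbon). For the measured compounds named here, this is the same kind of change as the one from compound 3 to compound 2, but not the same: in compound 4 the new group sits ortho to a fused ring and meta to a fused ring, while in compound 2 it sits meta to a fused ring, meta to a methoxy group and para to a fused ring. The difference between the core of compound 1 and the core of compound 3 is not broken down here.

Going by the values given here, the only guide is the measured step, and it was within the scatter. The step from compound 1 to compound 4 in this assay is therefore expected to be about a number 0.040 higher from compound 1 to compound 4 (within the scatter). Compound 4 is estimated to reach 0.62, most likely between 0.5 and 0.75.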

Compound 4, intrinsic activity: the largest response reached, as a fraction of the reference agonist's: 0.24
Compound 4: the middle estimate sits 0.38 above what was measured; the measured number lies below the stated range.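

In this assay, chloro in place of methyl on an aromatic carbon looks like the same change in both pairs, yet the new step is a number 0.34 lower from compound 1 to compound 4 (beyond the scatter), and it does not match the earlier one: the same change on two cores in this assay, a number 0.060 higher (within the scatter) from compound 3 to compound 2 and a number 0.34 lower (beyond the scatter) from compound 1 to compound 4, 0.40 apart, beyond the scatter of two such steps

So in this series, the effect of this change cannot be carried from one core to another as a fixed amount, and a step measured on one core is a poor guide to the same change on another. This does not show why the two steps part ways, since the pairs differ both in their core and in where the chloro sits, which in compound 4 is ortho to a fused ring and meta to a fused ring, and a single pair of each kind cannot separate these two differences.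

Going by these compounds, it remains open whether the lower response of compound 4 belongs to chloro itself or to any change away from methyl at that place on the core of compound 1. Other groups there, such as fluoro, bromo or an amine, could help settle this, as could chloro at another place on the same core.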